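A few compounds are considered here, and "the series" means these few. Any claim that something is new, unique, unknown or untested is made for them only; others in the source may bear on it.

Among the compounds with values here, compound 3, with the structure `O=C(CCCCCCc1ccccc1)c1nc(-c2ccccn2)co1`, stands at the strong end of the three compounds measured so far: in an assay on isolated protein for inhibition of Fatty-acid amide hydrolase 1 (Rattus norvegicus) (a lower number here means a stronger inhibitor, a higher number a weaker inhibitor), compound 3 gives 1.9 nM, the lowest number of the three. Its nearest neighbour is compound 2, with the structure `CSc1coc(C(=O)CCCCCCc2ccccc2)n1`, which in this assay gives 29 nM; furthest away is compound 1, with the structure `Cc1coc(C(=O)CCCCCCc2ccccc2)n1`, which gives 520 nM. The step from compound 3 to compound 4, with the structure `COc1coc(C(=O)CCCCCCc2ccccc2)n1`, is this: methoxy in place of pyridin-2-yl on an aromatic carbon. Within the data shown here, two measured steps bear on it. The step of an 18-fold lower number from compound 1 to compound 2 (1.25 log units; beyond the scatter) shows that a small group with one hydrogen-bond acceptor in this place does much better than methyl, while the step of a 15-fold lower number from compound 2 to compound 3 (1.18 log units; beyond the scatter) shows that pyridin-2-yl does much better still. Methoxy is closer in kind to methylsulfanyl than to pyridin-2-yl, so the author expects a large step toward a higher number for compound 4, of about a 32-fold higher number from compound 3 to compound 4 (1.50 log units; beyond the scatter). The estimate for compound 4 in this assay is therefore 60 nM, with a range from 15 nM to 250 nM.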

Compound 4, inhibition constant: 740 nM
Beside the measured number, compound 4's estimate is 12-fold (1.09 log units) below it; measured number above the stated range.
By their numbers in this assay, from the lowest: compound 3; then compound 2; then compounds 1 and 4 (each within the scatter of the next).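

In this assay methoxy does not behave like methylsulfanyl on this aromatic carbon: the exchange gives a 26-fold higher number from compound 2 to compound 4 (1.41 log units; beyond the scatter) and so loses what methylsulfanyl gained, while the exchange for methyl gives a 1.4-fold higher number from compound 1 to compound 4 (0.15 log units; within the scatter) and leaves methoxy level with methyl. Pyridin-2-yl and methoxy carry the same count of hydrogen-bond donors and acceptors, yet the exchange gives a 390-fold higher number from compound 3 to compound 4 (2.59 log units; beyond the scatter) and that count therefore does not sort these groups. Nothing available here accounts for these differences.

The compounds shown leave open where an amine, ethylsulfanyl or ethoxy would fall on this aromatic carbon. They also leave open whether a phenyl ring would match pyridin-2-yl, and so whether the ring nitrogen of that group matters.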